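The source may report more compounds than this note shows. Statements on the series, on what has been measured and on what is new or still open speak of the compounds shown alone.

Measured so far:
- compound 1, `Oc1ccc(-c2cc(-c3ccccc3F)cc(-c3cccc(O)c3)n2)cc1`: 6370 nM
- compound 2, `Oc1cccc(-c2cc(-c3cccc(C(F)(F)F)c3)cc(-c3cccc(O)c3)n2)c1`: 4970 nM

In a functional assay on T47D cells (Homo sapiens) for inhibition (on this read-out lower numbers stand for stronger inhibition and higher numbers for weaker inhibition), compound 2 gives 4970 nM, the lowest of the two numbers; compound 1 with 6370 nM sits close, and the gap between them is within the scatter, so no order between them can be claimed.

Compound 3, `Oc1ccc(-c2cc(-c3cccc(C(F)(F)F)c3)cc(-c3cccc(O)c3)n2)cc1`, is the not yet measured analogue of compound 2. The change is 4-hydroxyphenyl in place of 3-hydroxyphenyl on an aromatic carbon. Among the compounds with values here, no step between measured compounds exists for this exchange, so its size must be guessed. Compound 1 already carries a 4-hydroxyphenyl group alongside a 3-hydroxyphenyl group and gives 6370 nM, a number of the same order as compound 2, which suggests the exchange does little here.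

The step from compound 2 to compound 3 is therefore expected to be a 1.1-fold higher number from compound 2 to compound 3 (0.04 log units; within the scatter), not beyond the scatter in either direction. Compound 3 is estimated at 5500 nM, within 2500 nM to 12000 nM.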

Compound 3, half-maximal inhibitory concentration: 2630 nM
For compound 3 the middle estimate is 2.1-fold (0.32 log units) above the measured one, within the range that was stated.
By their numbers in this assay, from the lowest: compounds 3, 2 and 1 (each within the scatter of the next, the first and the last beyond it).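

In this assay, 4-hydroxyphenyl in place of 3-hydroxyphenyl on the aromatic carbon next to the ring nitrogen gives a 1.9-fold lower number from compound 2 to compound 3 (0.28 log units; within the scatter), so with a 3-(trifluoromethyl)phenyl group present, no preference between the two hydroxyl placings can be claimed at this position. The exchange of 2-fluorophenyl for 3-(trifluoromethyl)phenyl, with both hydroxyphenyl groups held constant, gives a 2.4-fold lower number from compound 1 to compound 3 (0.38 log units; beyond the scatter), a modest step and the only one in the series beyond the scatter. Nothing available bears on what lies behind the size of either step.

Open, on these data alone, is whether this position tolerates anything other than a hydroxyphenyl group, such as a methoxyphenyl, an aminophenyl or a carboxylic acid on the ring. Also open, as far as these compounds go, is whether the step from 2-fluorophenyl to 3-(trifluoromethyl)phenyl keeps its size when two 3-hydroxyphenyl groups are present.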